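This account rests on a few compounds, and the source may have more. Where it says the series, first, only, none or still open, it means among the compounds named here.

Measured compounds:
- compound 1, `CCC(C)NC(=O)/C=C/c1c(/C=C/c2ccc(OC)cc2)cc(OC)cc1OC`, gives 4380 nM in a functional assay on B16-F10 cells (Mus musculus) for inhibition, read by MTT assay, with a stated time of 48 h; a higher number here means a weaker inhibitor, a lower number a stronger inhibitor
- compound 2, `CCCCN(CCCC)C(=O)/C=C/c1c(/C=C/c2ccc(OC)cc2)cc(OC)cc1OC`, gives 9030 nM in this assay
- compound 3, `COc1ccc(/C=C/c2cc(OC)cc(OC)c2/C=C/C(=O)N2CCC(c3ccccc3)CC2)cc1`, gives 9180 nM in this assay

Compound 3 carries the highest number of the three in this assay; compound 2 sits within the scatter of it, while compound 1, the only secondary amide among the three, sits clearly lower. The next compound, compound 4, `CCNC(=O)/C=C/c1c(/C=C/c2ccc(OC)cc2)cc(OC)cc1OC`, has not yet been measured. It differs from compound 3 in one place: ethylamino in place of 4-phenylpiperidin-1-yl on a carbonyl carbon. Among the measured compounds shown here, two measured steps bear on this. The step of a 2.1-fold higher number from compound 1 to compound 3 (0.32 log units; beyond the scatter) shows that replacing a small secondary amide with the 4-phenylpiperidin-1-yl amide raised the number modestly; the step of a 1.0-fold higher number from compound 2 to compound 3 (0.01 log units; within the scatter) shows that the two tertiary amides are indistinguishable. Compound 4, a small secondary amide like compound 1, is therefore expected to reverse the first of these steps. The estimate for compound 4 is a modest drop, a 2.0-fold lower number from compound 3 to compound 4 (0.31 log units; beyond the scatter), landing close to compound 1, whose value 4380 nM is the anchor. Compound 4 is thus estimated at 4500 nM, with a range from 2000 nM to 10000 nM.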

Compound 4, half-maximal inhibitory concentration: 6990 nM
Beside the measured number, compound 4's estimate is 1.6-fold (0.19 log units) below it; the measured number falls inside the stated range.
By their numbers in this assay, from the lowest: compounds 1, 4, 2 and 3 (each within the scatter of the next, the first and the last beyond it).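

In this assay the change on the carbonyl carbon from 4-phenylpiperidin-1-yl, with 12 heavy atoms, to ethylamino, with 3 heavy atoms and 1 hydrogen-bond donor, leaves the number within the scatter (a 1.3-fold lower number from compound 3 to compound 4 (0.12 log units; within the scatter)), and the change from dibutylamino does the same (a 1.3-fold lower number from compound 2 to compound 4 (0.11 log units; within the scatter)). The change from (sec-butyl)amino to ethylamino also stays within the scatter (a 1.6-fold higher number from compound 1 to compound 4 (0.20 log units; within the scatter)), so compound 4 cannot be told apart from any of the other three. The gap between compound 1 and the two tertiary amides therefore does not separate compound 4, which also carries the amide hydrogen, from those tertiary amides.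

Nothing available here accounts for this result. The compounds shown leave open whether a morpholine amide, a longer straight chain on the amide nitrogen, or a carboxylic acid in place of the amide would move the number beyond the scatter.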